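The source may report more compounds than this note shows. Statements on the series, on what has been measured and on what is new or still open speak of the compounds shown alone.

Compound 2, `CCC/C=C\C(=O)Nc1cc(Nc2nc(C)cc(-c3cn(C)c4ccccc34)n2)c(OC)cc1N(C)CCN(C)C`: 254 nM in a functional assay on NCI-H1975 cells (Homo sapiens) for antiproliferative activity, read by MTT assay, with a stated time of 72 h; on this read-out lower numbers stand for stronger inhibition and higher numbers for weaker inhibition. Compound 1, `CC/C=C\C(=O)Nc1cc(Nc2nc(C)cc(-c3cn(C)c4ccccc34)n2)c(OC)cc1N(C)CCN(C)C`: 1990 nM.

Within the data shown here, compound 2 stands lowest of the two numbers; the only other is compound 1, and the one measured step, a 7.8-fold lower number from compound 1 to compound 2 (0.89 log units; beyond the scatter), concerns the chain on the amide, not the ring system. Compound 3, `CCC/C=C\C(=O)Nc1cc(Nc2nc(C)cc(-c3cn(C)c4ccc(F)cc34)n2)c(OC)cc1N(C)CCN(C)C`, differs from compound 2 by fluoro in place of hydrogen on an aromatic carbon. Among the measured compounds shown here, no measured step touches this part of the shared core, so nothing here points in either direction. The expected step of a 1.0-fold lower number from compound 2 to compound 3 (0.01 log units; within the scatter) is none beyond the scatter. Compound 3 is therefore estimated at 250 nM, within 80 nM to 800 nM in this assay.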

Compound 3, half-maximal inhibitory concentration: 12200 nM
For compound 3 the middle estimate is 49-fold (1.69 log units) below the measured one; the measured number lies above the stated range.
By their numbers in this assay, from the lowest: compound 2; then compound 1; then compound 3.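

Fluoro in place of hydrogen on this aromatic carbon adds only one heavy atom, yet it brings a 48-fold higher number from compound 2 to compound 3 (1.68 log units; beyond the scatter) and costs much of the activity of compound 2. This part of the shared core is therefore far from indifferent to change, at least with the chain of compound 2. No available evidence explains this loss. Going by these compounds, whether any group on this carbon would do the same remains open, and chloro or methoxy there would test it. Also open, on these data alone, is whether fluoro on another carbon of that ring behaves alike.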